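The compounds below may be only part of what the source reports. "The series", "measured", "known", "first", "only" and "open" are said of these compounds alone.

Two compounds stand measured here. Compound 1 `CC(=O)N1N=C(c2ccc(OCc3cn(Cc4ccc([N+](=O)[O-])cc4)nn3)cc2)CC1c1ccccc1` gives 80% in a functional assay on A549 cells (Homo sapiens) for inhibition, read by sulforhodamine B assay, tested at 100 uM (a lower number here means less inhibition of growth, a higher number more inhibition of growth at the concentration tested), while compound 2 `COc1cc(C2CC(c3ccc(Br)cc3)=NN2C(C)=O)ccc1OCc1cn(Cc2ccc([N+](=O)[O-])cc2)nn1` gives 17% in this assay. Compound 2 thus holds the lower of the two numbers, and its distance from compound 1 lies beyond the scatter of repeated runs. Among the compounds with values here, the two compounds differ in more than one place, so no single step can be drawn between them.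

Compound 3 `COc1cc(C2CC(c3cc(OC)c(OC)c(OC)c3)=NN2C(C)=O)ccc1OCc1cn(Cc2ccc([N+](=O)[O-])cc2)nn1` is the next compound to be measured. It is derived from compound 2 by a single change: 3,4,5-trimethoxyphenyl in place of 4-bromophenyl on a carbon with a double bond to nitrogen. Within the data shown here, no measured pair shows this change, so the size and direction of its effect in this assay are open. The spread between compound 1 and compound 2 shows that the aryl group on that carbon can move the read-out widely. A step of moderate size upward is expected, namely a number 23 percentage points higher from compound 2 to compound 3 (beyond the scatter). Compound 3 is therefore estimated at 40%, within a range from 10% to 75%.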

Compound 3, percent growth inhibition at one concentration: 85%
For compound 3 the middle estimate is 45 percentage points below the measured one, and the stated range ends below it.
By their numbers in this assay, from the lowest: compound 2; then compounds 1 and 3 (each within the scatter of the next).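

In this assay, the exchange of 4-bromophenyl for 3,4,5-trimethoxyphenyl on the carbon with a double bond to nitrogen gives a number 68 percentage points higher from compound 2 to compound 3 (beyond the scatter). Within the data shown here, this is the first reading of a single change at this position, and it shows that the aryl group there can by itself move the read-out by a large amount while the rest of compound 2 stays fixed. No measurement shown here accounts for the step.

Going by these compounds, this one pair cannot separate the departure of the bromine from the arrival of the three methoxy groups, so it remains open how a phenyl ring with a single methoxy group, or one carrying an amine or a carboxylic acid, would fare at this position. On these data alone, it also remains open whether the same exchange would give a step of similar size elsewhere on the shared core.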